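Dropping a methoxy group: growth inhibition expected to hold

This account rests on a few compounds, and the source may have more. Where it says the series, first, only, none or still open, it means among the compounds named here.

Within the data shown here, compound 2 `COc1ccc(-c2[nH]c3ccc(OC)cc3c2/C=C(\C#N)S(=O)(=O)c2ccccc2)cc1` gives 901 nM in a functional assay on SK-OV-3 cells (Homo sapiens) for inhibition, read by sulforhodamine B assay, with a stated time of 48 h (a lower number here means a stronger inhibitor of growth, a higher number a weaker inhibitor of growth), the highest of the two numbers so far; its nearest neighbour, compound 1 `COc1ccc(-c2[nH]c3ccccc3c2/C=C(\C#N)S(=O)(=O)c2ccccc2)cc1`, gives 528 nM, and a 1.7-fold higher number from compound 1 to compound 2 (0.23 log units; within the scatter) stays within the scatter. Compound 3 `COc1ccc2[nH]c(-c3ccccc3)c(/C=C(\C#N)S(=O)(=O)c3ccccc3)c2c1` is not yet measured; it differs from compound 2 by hydrogen in place of methoxy on an aromatic carbon, on an aromatic carbon of a six-membered aromatic ring of carbon only. Among the measured compounds shown here, the only measured step, from compound 1 to compound 2, concerned a methoxy at another place and stayed within the scatter, so no change beyond the scatter is expected here. Compound 3 is therefore estimated at 900 nM, between 400 nM and 2000 nM, an expected step of a 1.0-fold lower number from compound 2 to compound 3 (0.00 log units; within the scatter).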

Compound 3, concentration for 50% growth inhibition: 7100 nM
Compound 3: middle estimate off by 7.9-fold (0.90 log units), on the low side; the measured number lies above the stated range.
By their numbers in this assay, from the lowest: compounds 1 and 2 (each within the scatter of the next); then compound 3.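

Taking the methoxy off the 4-methoxyphenyl group, para to a large group, gives a 7.9-fold higher number from compound 2 to compound 3 (0.90 log units; beyond the scatter) in this assay. Among these compounds, this is the first step beyond the scatter, whereas the methoxy at the other place gave a 1.7-fold higher number from compound 1 to compound 2 (0.23 log units; within the scatter). The two methoxy places are therefore not interchangeable, and growth inhibition depends on the methoxy at this one.

Nothing shown here explains why this methoxy matters. From the compounds shown here alone, it also remains open whether a hydroxyl, an ethoxy or an amine at this place would match the methoxy or fall to the level of hydrogen.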